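This account rests on a few compounds, and the source may have more. Where it says the series, first, only, none or still open, it means among the compounds named here.

Compound 1 `O=C1C=CC(OCC(F)(F)F)N1c1ccccc1` gives 15300 nM in a functional assay on MDA-MB-231 cells (Homo sapiens) for inhibition; a higher number here means a weaker inhibitor, a lower number a stronger inhibitor.
Compound 2 `CC(C)(C)c1ccc(N2C(=O)C=CC2OCC(F)(F)F)cc1` gives 1860 nM in this assay.
Compound 3 `COC(=O)c1ccc(N2C(=O)C=CC2OCC(F)(F)F)cc1` gives 12100 nM in this assay.

Compound 3 stands second highest of these three numbers. Its gap to compound 1 is within the scatter, as the step of a 1.3-fold lower number from compound 1 to compound 3 (0.10 log units; within the scatter) shows, whereas the step of a 6.5-fold higher number from compound 2 to compound 3 (0.81 log units; beyond the scatter) lies beyond it.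

Compound 4 `O=C1C=CC(OCC(F)(F)F)N1c1ccc(C(F)(F)F)cc1` differs from compound 3 in one place: trifluoromethyl in place of methoxycarbonyl on an aromatic carbon. Within the data shown here, no measured step involves a trifluoromethyl group, so the guide is indirect: the step of an 8.2-fold lower number from compound 1 to compound 2 (0.92 log units; beyond the scatter) shows that a group at this position can lower the number, while the step of a 1.3-fold lower number from compound 1 to compound 3 (0.10 log units; within the scatter) shows that methoxycarbonyl does little. A modest lower number is therefore expected, a 2.4-fold lower number from compound 3 to compound 4 (0.38 log units; beyond the scatter). Compound 4 is estimated at 5000 nM, with a range from 1800 nM to 14000 nM.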

Compound 4, half-maximal inhibitory concentration: 2300 nM
The estimate for compound 4 lay 2.2-fold (0.34 log units) above the measured number, and the stated range covers the measured number.
By their numbers in this assay, from the lowest: compounds 2 and 4 (each within the scatter of the next); then compounds 3 and 1 (each within the scatter of the next).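

Trifluoromethyl is a second group at this position that clearly improves on the bare ring, with a 6.7-fold lower number from compound 1 to compound 4 (0.82 log units; beyond the scatter), and a 1.2-fold higher number from compound 2 to compound 4 (0.09 log units; within the scatter) leaves it indistinguishable from tert-butyl. Methoxycarbonyl does not share this gain: a 5.3-fold lower number from compound 3 to compound 4 (0.72 log units; beyond the scatter), even though the two exchanged groups have the same count of heavy atoms, so that count alone does not set the number here. Nothing measured on these compounds explains the difference. As far as these compounds go, whether an amine or a carboxylic acid on this carbon would track methoxycarbonyl or trifluoromethyl remains open, as does the outcome with a longer chain.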